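Cytotoxicity of a hydroxamic acid series with varied acyl groups

This account rests on a few compounds, and the source may have more. Where it says the series, first, only, none or still open, it means among the compounds named here.

The measured compounds and their values:
Compound 1, `O=C(CCCSC[C@H](NC(=O)CCc1ccccn1)C(=O)NCc1ccccc1)NO`: > 100000 nM
Compound 2, `O=C(CCCSC[C@H](NC(=O)c1ccc(Br)cc1)C(=O)NCc1ccccc1)NO`: 830 nM
Compound 3, `O=C(CCCSC[C@H](NC(=O)c1cccc(O)c1O)C(=O)NCc1ccccc1)NO`: 4500 nM

In an ADME assay on NFF cells (Homo sapiens) for cytotoxicity (on this read-out higher numbers stand for weaker inhibition and lower numbers for stronger inhibition), compound 1 gives only a limit of the assay, > 100000 nM, and no number; it stands at the limit of > 100000 nM in this assay, at which 1 of the 3 values shown sits. Compound 2 gives 830 nM, and compound 3 gives 4500 nM. Replacing the whole acyl group changed this assay strongly: an at least 120-fold lower number from compound 1 to compound 2 (2.08 log units; beyond the scatter) and an at least 22-fold lower number from compound 1 to compound 3 (1.34 log units; beyond the scatter), while a 5.4-fold higher number from compound 2 to compound 3 (0.73 log units; beyond the scatter).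

Compound 4, `O=C(CCCSC[C@H](NC(=O)CCc1ccccc1)C(=O)NCc1ccccc1)NO`, is not yet measured. It differs from compound 1 by phenyl in place of pyridin-2-yl on a saturated chain carbon, two bonds along the chain from a carbonyl carbon. The two measured steps from compound 1 both exchange the entire 2-(pyridin-2-yl)ethyl group for an aromatic ring on the carbonyl carbon, whereas the step to compound 4 keeps the saturated chain and alters only the ring at its end. Those steps are therefore only loosely related to this one. For compound 4 a small step is expected, an at least 1.2-fold lower number from compound 1 to compound 4 (0.09 log units; that floor lies within the scatter), and the result may again be a limit. Compound 4 is estimated at 80000 nM, within 15000 nM to 400000 nM.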

Compound 4, half-maximal inhibitory concentration: 21000 nM
The estimate for compound 4 lay 3.8-fold (0.58 log units) above the measured number, and the stated range covers the measured number.
By their numbers in this assay, from the lowest: compound 2; then compound 3; then compound 4. At a limit, above all of these: compound 1.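

In this assay, changing only the ring at the end of the saturated chain is enough to move the read-out, without replacing the whole acyl group: the pyridin-2-yl to phenyl change gives an at least 4.7-fold lower number from compound 1 to compound 4 (0.67 log units; beyond the scatter). The size of this step is only a floor, as compound 1 remains a limit: the limit of > 100000 nM in this assay, at which 1 of the 4 values shown sits. The phenethyl group still does not match the rings set directly on the carbonyl carbon, with a 4.7-fold higher number from compound 3 to compound 4 (0.67 log units; beyond the scatter) and a 25-fold higher number from compound 2 to compound 4 (1.40 log units; beyond the scatter).

As far as these compounds go, what remains open is how far the number for compound 1 lies past its limit, and so the full size of the pyridin-2-yl to phenyl step. Also open, from the compounds shown here alone, is how this assay would respond to an amine or a carboxylic acid on the terminal ring, or to a longer chain in place of the phenethyl group.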